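Moving two methyl groups on the aryl ring

This account rests on a few compounds, and the source may have more. Where it says the series, first, only, none or still open, it means among the compounds named here.

Measured in a functional assay on HL-60 cells (Homo sapiens) for inhibition, read by MTT assay, with a stated time of 72 h (a lower number here means a stronger inhibitor, a higher number a weaker inhibitor), so far
- Compound 1 `Cc1nc(-c2ccccc2)c(C(=O)N2CCN(c3cccc(Cl)c3)CC2)o1` gives 39.2 nM
- Compound 2 `Cc1nc(-c2ccc(F)cc2)c(C(=O)N2CCN(c3ccc(C(=O)C(C)C)cc3)CC2)o1` gives "not active" (no number reported)
- Compound 3 `Cc1ccc(N2CCN(C(=O)c3oc(C)nc3-c3ccccc3)CC2)c(C)c1` gives 101 nM

Compound 3 holds the higher of the two numbers in this assay and is the weaker of the two inhibitors that have one, while compound 2 has no number at all. Compound 4 `Cc1cc(C)cc(N2CCN(C(=O)c3oc(C)nc3-c3ccccc3)CC2)c1` has the same atoms as compound 3, joined differently, in one place: 3,5-dimethylphenyl in place of 2,4-dimethylphenyl on an amine nitrogen in a ring and the rest is unchanged. Among the compounds with values here, only one measured step bears on this place, a 2.6-fold higher number from compound 1 to compound 3 (0.41 log units; beyond the scatter) and it is modest. Within the data shown here, compound 2 differs from the others in more than one place and offers no step. The name 3,5-dimethylphenyl stands closer to the 3-chlorophenyl of compound 1 at 39.2 nM than 2,4-dimethylphenyl does, so a small shift toward a lower number is expected, perhaps no larger than the scatter. The estimated change is a 1.6-fold lower number from compound 3 to compound 4 (0.19 log units; within the scatter) and it rests on that single comparison. For compound 4 the expected value is 65 nM with an estimated range from 20 nM to 200 nM as the likely span.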

Compound 4, half-maximal inhibitory concentration: 34.5 nM
Estimate against measurement, compound 4: 1.9-fold (0.28 log units) above; the range from low to high includes it.
By their numbers in this assay, from the lowest: compounds 4 and 1 (each within the scatter of the next); then compound 3.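

Swapping 2,4-dimethylphenyl for 3,5-dimethylphenyl on the amine nitrogen gives a 2.9-fold lower number from compound 3 to compound 4 (0.47 log units; beyond the scatter) in this assay with no atom gained or lost, so the arrangement of the two methyl groups on this aryl ring is enough on its own to move the number beyond the scatter. Set against 3-chlorophenyl, the 3,5-dimethylphenyl group gives a 1.1-fold lower number from compound 1 to compound 4 (0.06 log units; within the scatter) and the two groups cannot be told apart here, so a chlorine and two methyl groups can read alike at this position. Nothing at hand says why the arrangement of the methyl groups matters in this assay.

On these data alone, how a plain phenyl, a 3-methylphenyl or a 3-methoxyphenyl would read at this position remains open. As far as these compounds go, it is also open whether a 3,5-dichlorophenyl would read like compound 4.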